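One More Group Exchange on a Shared Core

The compounds below may be only part of what the source reports. "The series", "measured", "known", "first", "only" and "open" are said of these compounds alone.

Measured so far:
compound 1 `N=C(Cn1c(-c2ccco2)nc2ccccc21)NN`: 74500 nM
compound 2 `S=c1[nH]nc(Cn2c(-c3ccco3)nc3ccccc32)s1`: 47600 nM

Within the data shown here, in a functional assay on HepG2 cells (Homo sapiens) for cytotoxicity, read by sulforhodamine B assay, with a stated time of 48 h (a lower number here means a stronger inhibitor, a higher number a weaker inhibitor), compound 2 gives 47600 nM, within the scatter of compound 1, the only other compound measured. Compound 3 `N=C1N=C(n2c(-c3ccco3)nc3ccccc32)CN1` changes the same part of the molecule: a group of 6 heavy atoms (3 carbon, 3 nitrogen; one five-membered non-aromatic ring with 2 hetero atoms) in place of a group of 7 heavy atoms (3 carbon, 2 nitrogen, 2 sulfur; one five-membered aromatic ring with 3 hetero atoms), on an aromatic nitrogen. Among the measured compounds shown here, one measured step bears on this, a 1.6-fold lower number from compound 1 to compound 2 (0.19 log units; within the scatter). That exchange was made on a saturated chain carbon bound to an aromatic nitrogen, so it is only a loose guide. The step expected here is a 1.1-fold higher number from compound 2 to compound 3 (0.02 log units; within the scatter), with nothing beyond the scatter anticipated. The estimate for compound 3 is 50000 nM, with an expected range of 15000 nM to 120000 nM.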

Compound 3, half-maximal inhibitory concentration: 63500 nM
The estimate for compound 3 lay 1.3-fold (0.10 log units) below the measured number, and the stated range covers the measured number.
By their numbers in this assay, from the lowest: compounds 2, 3 and 1 (each within the scatter of the next).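

In this assay, the group holding a five-membered non-aromatic ring, which has no sulfur, gives a 1.3-fold higher number from compound 2 to compound 3 (0.13 log units; within the scatter) and a 1.2-fold lower number from compound 1 to compound 3 (0.07 log units; within the scatter). Among these compounds, an open group, an aromatic ring and a non-aromatic ring on the shared core therefore all lie within the scatter of one another, which the single earlier step could not show. No measured evidence bears on why these exchanges leave the number within the scatter. As far as these compounds go, whether a carboxylic acid, a simple amine or a longer chain in this part of the molecule would give a step beyond the scatter remains open.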